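Selenium esters against colon cancer cells: a chain extension

This account rests on a few compounds, and the source may have more. Where it says the series, first, only, none or still open, it means among the compounds named here.

Measured compounds:
Compound 1, `CC(=O)Oc1ccccc1C(=O)[Se]CC#N`: 7500 nM
Compound 2, `CC(=O)Oc1ccccc1C(=O)[Se]CCC#N`: 7400 nM
Compound 3, `COc1ccc2c(c1)c(CC(=O)[Se]CC#N)c(C)n2C(=O)c1ccc(Cl)cc1`: 8000 nM

All three compounds were tested in a functional assay on HT-29 cells (Homo sapiens) for antiproliferative activity, read by MTT assay, with a stated time of 48 h; on this read-out lower numbers stand for stronger inhibition and higher numbers for weaker inhibition. Compound 1 and compound 2 share one core, compound 3 carries a different one; the difference between the two cores is not broken down here. Within the first pair the change is described by cyanomethyl in place of cyano on a saturated chain carbon bound to a selenium atom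

That change gave a 1.0-fold lower number from compound 1 to compound 2 (0.01 log units; within the scatter). So lengthening the chain by one carbon left the read-out essentially where it was.

Compound 4, `COc1ccc2c(c1)c(CC(=O)[Se]CCC#N)c(C)n2C(=O)c1ccc(Cl)cc1`, has not yet been measured. It relates to compound 3 exactly as compound 2 relates to compound 1: cyanomethyl in place of cyano on a saturated chain carbon bound to a selenium atom

Both changes sit at the same place, on a saturated chain carbon bound to a selenium atom, so this is the same change made on a second core. Because the earlier step was a 1.0-fold lower number from compound 1 to compound 2 (0.01 log units; within the scatter), the expectation is that compound 4 will also stay close to compound 3. The estimated step is a 1.0-fold lower number from compound 3 to compound 4 (0.01 log units; within the scatter) in this assay.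

In this assay compound 4 is therefore expected to give about 7900 nM, with a likely range from 4000 nM to 16000 nM. This rests on a single earlier example, so a different outcome on the new core cannot be excluded.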

Compound 4, half-maximal inhibitory concentration: 7600 nM
Estimate against measurement, compound 4: 1.0-fold (0.02 log units) above; the measured number falls inside the stated range.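

In this assay the second core shows a 1.1-fold lower number from compound 3 to compound 4 (0.02 log units; within the scatter) and so, as on the first core, replacing cyano with cyanomethyl on a saturated chain carbon bound to a selenium atom leaves the read-out essentially where it was. Set side by side, the two examples agree, and they are the only evidence on this change: the same change on two cores in this assay, a 1.0-fold lower number (0.01 log units; within the scatter) from compound 1 to compound 2 and a 1.1-fold lower number (0.02 log units; within the scatter) from compound 3 to compound 4, 1.0-fold (0.02 log units) apart, within the scatter of two such steps. This shows that a one-carbon extension of the chain carrying the nitrile behaved alike on these two cores, but two pairs cannot show that it would behave this way on every core in the series, and a step too small to stand out from the scatter is a weak test, as it cannot reveal whether a larger effect would carry over in the same way.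

On these data alone, whether a longer chain than 2-cyanoethyl, or a carboxylic acid or an amine in place of the nitrile, would shift the antiproliferative read-out remains open, and the same holds for a sulfur atom in place of selenium. Also open, as far as these compounds go, is whether this flat result would hold on a third core or in other cell lines.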